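Aryl amide variation on the shared core: compound 4 outlook

The compounds below may be only part of what the source reports. "The series", "measured", "known", "first", "only" and "open" are said of these compounds alone.

Measured:
compound 1 `O=C(CN1CCC(c2cccc[n+]2[O-])CC1)Nc1cccc(F)c1` — 160 nM
compound 2 `Cc1cc(Br)ccc1NC(=O)CN1CCC(c2cccc[n+]2[O-])CC1` — 66 nM
compound 3 `O=C(CN1CCC(c2cccc[n+]2[O-])CC1)Nc1ccc(F)cc1` — 85 nM

In a functional assay on HEK293 cells for agonist activity at D(4) dopamine receptor (Homo sapiens), read by FLIPR (a higher number here means that more compound is needed for the effect, a lower number that less compound is needed), compound 3 gives 85 nM, the second highest of the three numbers. Nearest neighbour: a 1.3-fold higher number from compound 2 to compound 3 (0.11 log units; within the scatter). Furthest: a 1.9-fold lower number from compound 1 to compound 3 (0.27 log units; within the scatter).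

Compound 4 `O=C(CN1CCC(c2cccc[n+]2[O-])CC1)Nc1cccc(Cl)c1` differs from compound 3 by 3-chlorophenyl in place of 4-fluorophenyl on an amide-type nitrogen. Among the measured compounds shown here, two measured steps bear on it. The move of fluorine between ring positions, a 1.9-fold lower number from compound 1 to compound 3 (0.27 log units; within the scatter), stayed within the scatter. The exchange of halogen with an added methyl, a 2.4-fold lower number from compound 1 to compound 2 (0.38 log units; beyond the scatter), was modest but beyond the scatter. Compound 4 carries its halogen on the 3-chlorophenyl ring as compound 1 does on the 3-fluorophenyl ring, so the expected step is small and, if anything, toward a higher number: a 1.4-fold higher number from compound 3 to compound 4 (0.15 log units; within the scatter). The estimate for compound 4 is 120 nM, range 50 nM to 300 nM.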

Compound 4, half-maximal effective concentration: 62 nM
The estimate for compound 4 lay 1.9-fold (0.29 log units) above the measured number; low and high end bracket the measured number.
By their numbers in this assay, from the lowest: compounds 4, 2, 3 and 1 (each within the scatter of the next, the first and the last beyond it).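

Chloro in place of fluoro on an aromatic carbon gives the first halogen exchange in the series that can be read in this assay (a 2.6-fold lower number from compound 1 to compound 4 (0.41 log units; beyond the scatter)), and it lies beyond the scatter. The 3-chlorophenyl group does not share the number of compound 1, yet it stays within the scatter of the other aryl amides (a 1.4-fold lower number from compound 3 to compound 4 (0.14 log units; within the scatter); a 1.1-fold lower number from compound 2 to compound 4 (0.03 log units; within the scatter)). No measurement shown accounts for the chloro-fluoro step.

Open, going by these compounds, is whether bromo or methoxy in place of chloro on that aromatic carbon would extend this step. Also open, on these data alone, is how an amine or carboxylic acid on the aryl ring would read here.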